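Shortening one side of a symmetric acylguanidine

This account rests on a few compounds, and the source may have more. Where it says the series, first, only, none or still open, it means among the compounds named here.

Measured so far:
compound 1, `CC(C)=CC(=O)NC(=N)NC(=O)C=C(C)C`: > 100000 nM
compound 2, `CC(C)=CCC/C(C)=C/C(=O)NC(=N)N`: 56300 nM
compound 3, `CC(C)=CCC/C(C)=C/CC/C(C)=C/C(=O)NC(=N)NC(=O)/C=C(\C)CCC=C(C)C`: 57300 nM

Compound 1 gives only a limit of the assay, (the limit of > 100000 nM in this assay, at which 1 of the 3 values shown sits), and not a number. In a functional assay on SK-MEL-28 cells (Homo sapiens) for inhibition, read by MTT assay, with a stated time of 72 h (a lower number here means a stronger inhibitor of growth, a higher number a weaker inhibitor of growth), compound 2 gives 56300 nM, and compound 3 gives 57300 nM. Compound 3 thus holds the higher of the two numbers, but its gap to compound 2 is within the scatter, so the two cannot be told apart.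

Compound 4, `CC(C)=CCC/C(C)=C/C(=O)NC(=N)NC(=O)C=C(C)C`, has not yet been measured. It arises from compound 3 by the change (hydrogen in place of 3,7-dimethylocta-2,6-dien-1-yl on a saturated chain carbon bound to a double-bonded chain carbon). The chain that leaves is one of the two long ones; the other long chain and the acylguanidine core remain.

Among the compounds seen, the one with the shorter pieces on both sides reaches only the limit, while a single long chain gives a number close to that of compound 3. Compound 4 sits between these cases, so the step of a 1.2-fold higher number from compound 3 to compound 4 (0.09 log units; within the scatter) is expected to be small, leaning weaker, or none beyond the scatter. Compound 4 is therefore estimated at 70000 nM, within 30000 nM to 160000 nM.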

Compound 4, concentration for 50% growth inhibition: 53400 nM
Estimate against measurement, compound 4: 1.3-fold (0.12 log units) above; the measured number falls inside the stated range.
By their numbers in this assay, from the lowest: compounds 4, 2 and 3 (each within the scatter of the next). At a limit, above all of these: compound 1.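

In this assay, hydrogen in place of 3,7-dimethylocta-2,6-dien-1-yl on a saturated chain carbon bound to a double-bonded chain carbon gives a 1.1-fold lower number from compound 3 to compound 4 (0.03 log units; within the scatter), so the second long chain makes no difference that can be read here. Placing (2-methylprop-1-en-1-yl)carbonyl in place of hydrogen on an amine nitrogen gives a 1.1-fold lower number from compound 2 to compound 4 (0.02 log units; within the scatter), so that group cannot be told apart from hydrogen either. Against compound 1, whose value is only a limit of the assay, the step is an at least 1.8-fold lower number from compound 1 to compound 4 (0.27 log units; that floor lies within the scatter), a floor that does not settle whether the one remaining long chain matters.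

From the compounds shown here alone, it stays open whether a longer chain, or a chain ending in an amine or a carboxylic acid, would move the number beyond the scatter. The three compounds with numbers lie within the scatter of each other, so they do not show which part of the structure governs growth inhibition.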